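A few compounds are considered here, and "the series" means these few. Any claim that something is new, unique, unknown or untested is made for them only; others in the source may bear on it.

Compounds measured so far: compound 1, `N=C(N)c1ccc(-c2ccc(-c3cncc4ccccc34)s2)s1`, with 1910 nM in a functional assay on NCI-H226 cells (Homo sapiens) for inhibition, read by sulforhodamine B assay, with a stated time of 48 h; on this read-out higher numbers stand for weaker inhibition of growth and lower numbers for stronger inhibition of growth; compound 2, `N=C(N)c1ccc(-c2ccc(-c3ccc(F)cc3)o2)o1`, with 2820 nM in the same assay.

Compound 2 has the highest of the two numbers in this assay, and its nearest neighbour is compound 1, a gap that lies within the scatter. Compound 3, `N=C(N)c1ccc(-c2ccc(-c3ccc(Cl)cc3)o2)o1`, differs from compound 2 only by chloro in place of fluoro on an aromatic carbon. For the measured compounds named here, no step between measured compounds covers such a change, so only a small shift is expected, at most a modest move toward stronger inhibition and possibly none beyond the scatter. For compound 3 the expected step is a 1.3-fold lower number from compound 2 to compound 3 (0.11 log units; within the scatter). Compound 3 is therefore estimated at 2200 nM, within 800 nM to 6000 nM.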

Compound 3, concentration for 50% growth inhibition: 2190 nM
Compound 3: the middle estimate sits 1.0-fold (0.00 log units) above what was measured, and the stated range covers the measured number.
By their numbers in this assay, from the lowest: compounds 1, 3 and 2 (each within the scatter of the next).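

In this assay, for the compounds shown here, chloro in place of fluoro on an aromatic carbon, para to a large group, gives a 1.3-fold lower number from compound 2 to compound 3 (0.11 log units; within the scatter) and so provides the first comparison here of compounds differing in one place. At this position, the two halogens cannot be told apart in growth inhibition. No measured evidence bears on this result.

On these data alone, it remains open whether an amine or a carboxylic acid on that aromatic carbon would shift the number beyond the scatter. As far as these compounds go, it is also open whether chloro and fluoro would stay indistinguishable on the core of compound 1.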